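Aryl exchange on the nitrogen of compound 1

The source may hold more compounds than are shown below. What is called first, only, known or untested is meant among the compounds shown, and "the series" means these compounds.

Measured so far:
compound 1 `COc1cc(NC(=O)Nc2cc(Nc3ccc(C)c(F)c3)ncn2)cc(OC)c1`: 39.7%
compound 2 `COc1cc(Br)ccc1Nc1cc(NC(=O)Nc2c(Cl)cccc2Cl)ncn1`: 43%
compound 3 `CC(C)(C)c1ccc(Nc2cc(NC(=O)Nc3c(Cl)cccc3Cl)ncn2)cc1`: 40%

In a functional assay on NCI-H226 cells (Homo sapiens) for inhibition, read by MTT assay, with a stated time of 48 h, tested at 10 uM (on this read-out higher numbers stand for more inhibition at the one concentration tested (going by the name of the read-out) and lower numbers for less inhibition), compound 1 gives 39.7%. This is the lowest of the three numbers, but the gap to compound 3 and the gap to compound 2 both lie within the scatter, so no order among the three is read from them; they sit in one band of moderate inhibition at the single concentration tested.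

Compound 4 `COc1cc(NC(=O)Nc2cc(Nc3ccc(OC)c(C)c3)ncn2)cc(OC)c1` differs from compound 1 in one place: 4-methoxy-3-methylphenyl in place of 3-fluoro-4-methylphenyl on a nitrogen on an aromatic ring. Among the compounds with values here, no pair of measured compounds differing in a single place is available, so the size of this kind of step has no precedent within the set. What the set does show is that three compounds with different aryl groups on that nitrogen and different groups elsewhere all fall within the scatter of one another. On that basis the step from compound 1 to compound 4 is expected to stay within the scatter, with no clear direction. Compound 4 is therefore expected to give 40%, between 26% and 55%. The expected step of a number 0.3 percentage points higher from compound 1 to compound 4 (within the scatter) is within the scatter.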

Compound 4, a percentage reported as inhibition, at one concentration (the size of the read-out at that concentration, not a potency): 39.7%
Compound 4: middle estimate off by 0.3 percentage points, on the high side; low and high end bracket the measured number.
By their numbers in this assay, from the lowest: compounds 1, 4, 3 and 2 (each within the scatter of the next).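

Within the data shown here, this is the first single-place comparison: in this assay, 4-methoxy-3-methylphenyl in place of 3-fluoro-4-methylphenyl on a nitrogen on an aromatic ring gives no change at the digits printed from compound 1 to compound 4 (within the scatter). Among these compounds, compounds 2 and 3 differ from compound 1 in more than one place, so only this pair isolates the aryl group on that nitrogen, where exchanging fluorine for a methoxy oxygen and adding a hydrogen-bond acceptor leaves the read-out within the scatter. Nothing available bears on why the read-out holds across this change.

Still open, going by these compounds, is whether a more distant change on this nitrogen, such as a piperazine or a carboxylic acid on the aryl ring, would move the number beyond the scatter. A single concentration also leaves open whether compound 1 and compound 4 would match in potency.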